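Ethyl for Pyridin-2-yl on the Core Nitrogen

The compounds below may be only part of what the source reports. "The series", "measured", "known", "first", "only" and "open" are said of these compounds alone.

Series notes on the shared core carrying a carboxy group and a biaryl arm. Compound 1 `O=C(O)c1cc(-c2ccc(-c3ccc(Cl)cc3Cl)cc2)n(-c2ccccn2)n1` is measured in an assay on isolated protein for inhibition of methionine--tRNA ligase, cytoplasmic (Homo sapiens); a higher number here means a weaker inhibitor, a lower number a stronger inhibitor. For compound 1 the result is not a number but a limit of the assay, > 100000 nM. Among the measured compounds shown here, the one other measured member, compound 2 `O=C(O)c1cc(-c2ccc(-c3ccc(F)cc3)cc2)n(-c2ccc(Cl)cc2Cl)n1`, carries a different group on the same aromatic nitrogen and a different halogen pattern on the outer ring; in this assay compound 2 gives 41300 nM. For the measured compounds named here, no single-change pair among the measured compounds exists, so the size of any step here is untested. Compound 1 stands at the weak edge of what is known, with the limit of > 100000 nM in this assay, at which 1 of the 2 values shown sits.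

Compound 3 `CCn1nc(C(=O)O)cc1-c1ccc(-c2ccc(Cl)cc2Cl)cc1`, not yet measured, differs from compound 1 in one place: ethyl in place of pyridin-2-yl on an aromatic nitrogen. With only a limit at the starting point, the step in this assay is expected to be small or none beyond the scatter, with the estimate an at least 1.1-fold lower number from compound 1 to compound 3 (0.04 log units; that floor lies within the scatter) treated as a guess. Compound 3 is expected to give about 90000 nM in this assay, within 30000 nM to 300000 nM, with a fair chance that only a limit is reported again.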

Compound 3, half-maximal inhibitory concentration: 46400 nM
Compound 3: the middle estimate sits 1.9-fold (0.29 log units) above what was measured; the range from low to high includes it.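

In this assay, among the compounds shown here, ethyl in place of pyridin-2-yl on the aromatic nitrogen gives an at least 2.1-fold lower number from compound 1 to compound 3 (0.33 log units; beyond the scatter), the first sign that the group at this position can move the read-out beyond the scatter. The result for compound 1 is a limit of the assay and not a number, so this step gives only a floor and its full size cannot be read: the limit of > 100000 nM in this assay, at which 1 of the 3 values shown sits. Compound 3, with ethyl and no ring on this nitrogen, gives 46400 nM in this assay, so a pyridin-2-yl ring at this position is not needed for a numerical reading.

The compounds shown leave open whether a longer chain such as butyl, or a plain phenyl ring, on this nitrogen would give a lower number than ethyl does. Also open, going by these compounds, are whether an amide in place of the carboxy group would hold the value of compound 3 and what the halogen pattern on the outer ring contributes, since compound 2 differs from the other compounds in more than one place.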